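Swapping the aryl arm: a naphthyl variant awaits testing

The source may report more compounds than this note shows. Statements on the series, on what has been measured and on what is new or still open speak of the compounds shown alone.

Compound 1 `c1ccc2c(-c3cn4ccnc4c(-c4ccc5ncn(C6CCCCC6)c5c4)n3)cccc2c1` gives 22.9% in a functional assay on RPMI-8226 cells (Homo sapiens) for inhibition, read by sulforhodamine B assay, with a stated time of 48 h, tested at 10 uM; on this read-out lower numbers stand for less inhibition and higher numbers for more inhibition at the one concentration tested (going by the name of the read-out).
Compound 2 `CCc1ccc(-c2cn3ccnc3c(-c3ccc4ncn(Cc5ccccc5)c4c3)n2)cc1` gives 55.4% in this assay.
Compound 3 `Cc1cccc(-c2cn3ccnc3c(-c3ccc4ncn(Cc5ccccc5)c4c3)n2)c1` gives 37.5% in this assay.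

All three share one core and differ only in the groups hung on its two ends. Compound 3 stands second highest of the three: compound 1 sits below it by more than the usual scatter, and compound 2 sits above it by more than the usual scatter. Within the data shown here, the only pair that differs in a single place is the step of a number 17.9 percentage points lower from compound 2 to compound 3 (beyond the scatter), a modest drop from one aryl group to another.

Compound 4 `c1ccc(Cn2cnc3ccc(-c4nc(-c5cccc6ccccc56)cn5ccnc45)cc32)cc1` has not yet been measured. It differs from compound 3 in one place: naphthalen-1-yl in place of 3-methylphenyl on an aromatic carbon. Among the measured compounds shown here, no measured pair isolates this particular exchange. Compound 1 also carries naphthalen-1-yl, but it differs from compound 3 in a second place as well, so its low value only shows that a naphthalen-1-yl compound can land at the bottom of this small set. For the measured compounds named here, the one clean step, from 4-ethylphenyl to 3-methylphenyl, shows that changing this aryl group can shift the read-out modestly. I therefore expect a modest step, more likely downward than upward, of a number 7.5 percentage points lower from compound 3 to compound 4 (within the scatter). Compound 4 is expected to give about 30%, within a range from 15% to 48%.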

Compound 4, a percentage reported as inhibition, at one concentration (the size of the read-out at that concentration, not a potency): 26.9%
Estimate against measurement, compound 4: 3.1 percentage points above; the range from low to high includes it.
By their numbers in this assay, from the lowest: compounds 1 and 4 (each within the scatter of the next); then compound 3; then compound 2.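

With the benzyl group held fixed, both exchanges to naphthalen-1-yl at this position on the shared core lower the read-out in this assay: one is a number 10.6 percentage points lower from compound 3 to compound 4 (beyond the scatter), and the other, larger one is a number 28.5 percentage points lower from compound 2 to compound 4 (beyond the scatter). Among the three aryl groups carrying this benzyl group, 4-ethylphenyl therefore gives the highest number, 3-methylphenyl the middle one and naphthalen-1-yl the lowest, so going from the one carbon ring of 3-methylphenyl to the two of naphthalen-1-yl reduces inhibition here. Among these compounds, the other end of the molecule can now be read for the first time: with naphthalen-1-yl in place, benzyl in place of cyclohexyl on an aromatic nitrogen gives a number 4 percentage points higher from compound 1 to compound 4 (within the scatter), so these two groups cannot be told apart in this pair.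

Nothing at hand explains why the aryl groups fall in this order. The compounds shown leave open whether a phenyl ring carrying an amine or a carboxylic acid at this position would match compound 2 at 55.4%, and whether benzyl and cyclohexyl would still be indistinguishable with 4-ethylphenyl in place of naphthalen-1-yl.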